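This account rests on a few compounds, and the source may have more. Where it says the series, first, only, none or still open, it means among the compounds named here.

Measured so far in a functional assay on WI-38 VA13 cells (Homo sapiens) for cytotoxicity; a lower number here means that less compound is needed, a higher number that more compound is needed for the effect:
Compound 1 `O=C(Nc1ccc2nc(NC(=O)C3CCCCC3)sc2c1)c1ccccc1C(F)(F)F` gives 0.024 ug/mL.
Compound 3 `Cc1cc(C(=O)Nc2ccc3nc(NC(=O)C4CCCCC4)sc3c2)n(C)n1` gives 0.12 ug/mL.
Compound 2 `O=C(Nc1ccc2nc(NC(=O)C3CCCCC3)sc2c1)c1ccc(Cl)cc1Cl` gives > 4 ug/mL, which is a limit of this assay and not a number (the limit of > 4 ug/mL in this assay, at which 1 of the 3 values shown sits).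

Within the data shown here, compound 1 stands lowest of the two numbers known in this assay; its nearest neighbour is compound 3, with a 5.0-fold higher number from compound 1 to compound 3 (0.70 log units; beyond the scatter). The third compound, compound 2, sits at the limit.

Not yet measured is compound 4 `Cc1coc(C)c1C(=O)Nc1ccc2nc(NC(=O)C3CCCCC3)sc2c1`. It differs from compound 1 in one place: 2,4-dimethylfuran-3-yl in place of 2-(trifluoromethyl)phenyl on a carbonyl carbon.

Two measured steps start from compound 1 and exchange the same 2-(trifluoromethyl)phenyl on the carbonyl carbon. For 2,4-dichlorophenyl the outcome was an at least 160-fold higher number from compound 1 to compound 2 (2.22 log units; beyond the scatter). For 1,3-dimethyl-1H-pyrazol-5-yl, a five-membered aromatic ring carrying two methyls, the outcome was a 5.0-fold higher number from compound 1 to compound 3 (0.70 log units; beyond the scatter). Between those two, an at least 33-fold lower number from compound 2 to compound 3 (1.52 log units; beyond the scatter). The 2,4-dimethylfuran-3-yl of compound 4 is likewise a five-membered aromatic ring with two methyls, so the step to compound 3 is taken as the closer guide, and a modest rise in this assay is expected rather than a loss to the limit.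

Compound 4 is therefore estimated at 0.12 ug/mL in this assay, expected to fall between 0.03 ug/mL and 0.6 ug/mL. This corresponds to an expected 5.0-fold higher number from compound 1 to compound 4 (0.70 log units; beyond the scatter).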

Compound 4, half-maximal effective concentration: 2.7 ug/mL
For compound 4 the middle estimate is 23-fold (1.35 log units) below the measured one; the whole stated range lies below it.
By their numbers in this assay, from the lowest: compound 1; then compound 3; then compound 4. At a limit, above all of these: compound 2.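

Ring size and the count of methyls do not settle the outcome at this position on the carbonyl carbon: in this assay, 2,4-dimethylfuran-3-yl and 1,3-dimethyl-1H-pyrazol-5-yl, both five-membered aromatic rings with two methyls, are separated by a large step (a 23-fold higher number from compound 3 to compound 4 (1.35 log units; beyond the scatter)), and leaving 2-(trifluoromethyl)phenyl for the furan costs far more than the pyrazole change did (a 110-fold higher number from compound 1 to compound 4 (2.05 log units; beyond the scatter)). The five-membered rings therefore do not behave as one class here, and a high number in this series is no longer confined to the 2,4-dichlorophenyl compound, although the comparison with it yields only a floor that lies within the scatter (an at least 1.4-fold lower number from compound 2 to compound 4 (0.17 log units; that floor lies within the scatter)), so it sets no order between the two. Compound 2 stands at a limit of the assay and not at a number: the limit of > 4 ug/mL in this assay, at which 1 of the 4 values shown sits.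

The compounds shown do not separate the effect of the furan oxygen from that of the methyl placement, and an unsubstituted furan or a furan with its methyls elsewhere would bear on that. Equally open, on these data alone, is how a plain phenyl, a 2-methylphenyl or a ring carrying an amine or a carboxylic acid would fall at this carbonyl carbon.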